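A few compounds are considered here, and "the series" means these few. Any claim that something is new, unique, unknown or untested is made for them only; others in the source may bear on it.

Working notes on the series. The shared core carries the ethyl ester-bearing aryl group throughout; the compounds differ only in the group on a saturated chain carbon bound to an aromatic nitrogen. Within the data shown here, in a functional assay on cells (Platelet, Homo sapiens) for inhibition (on this read-out lower numbers stand for stronger inhibition and higher numbers for weaker inhibition), compound 1 `CCOC(=O)c1ccc(-c2nn(Cc3ccc(Cl)cc3)c3ccccc23)cc1` gives 120 nM, the lowest of the three numbers measured so far. Compound 2 `CCOC(=O)c1ccc(-c2nn(Cc3ccncc3)c3ccccc23)cc1` gives 5630 nM in this assay, and compound 3 `CCOC(=O)c1ccc(-c2nn(CC)c3ccccc23)cc1` gives 360 nM. The steps are a 47-fold higher number from compound 1 to compound 2 (1.67 log units; beyond the scatter), a 3.0-fold higher number from compound 1 to compound 3 (0.48 log units; beyond the scatter) and a 16-fold lower number from compound 2 to compound 3 (1.19 log units; beyond the scatter).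

Compound 4 `CCCn1nc(-c2ccc(C(=O)OCC)cc2)c2ccccc21` is not yet measured in this assay. It differs from compound 1 as follows: ethyl in place of 4-chlorophenyl on a saturated chain carbon bound to an aromatic nitrogen. Among the measured compounds shown here, the step that bears most directly on this is the one from compound 1 to compound 3, where a 3.0-fold higher number from compound 1 to compound 3 (0.48 log units; beyond the scatter) accompanied the change to methyl at the same place; the change to ethyl at that place differs from it by a single chain carbon. The step to compound 2 is a different kind of change and gives no guidance here. A modest rise in the number, of about the size seen for compound 3, is therefore expected for compound 4, with a 2.5-fold higher number from compound 1 to compound 4 (0.40 log units; beyond the scatter) as the expected step. The estimate for compound 4 in this assay is 300 nM, with a range from 100 nM to 900 nM.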

Compound 4, half-maximal inhibitory concentration: 490 nM
The estimate for compound 4 lay 1.6-fold (0.21 log units) below the measured number; the measured number falls inside the stated range.
By their numbers in this assay, from the lowest: compound 1; then compounds 3 and 4 (each within the scatter of the next); then compound 2.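

Adding a chain carbon at this position, which turns the ethyl of compound 3 into the propyl of compound 4, gives a 1.4-fold higher number from compound 3 to compound 4 (0.13 log units; within the scatter) in this assay, so the two short alkyl groups cannot be told apart on this read-out and chain length over this small range has no readable effect. Compound 1 keeps the lowest number with a second alkyl comparison in hand, a 4.1-fold higher number from compound 1 to compound 4 (0.61 log units; beyond the scatter), so its edge over the short alkyl groups now rests on two compounds rather than one, while an 11-fold lower number from compound 2 to compound 4 (1.06 log units; beyond the scatter) confirms with a second alkyl comparison that the pyridin-4-yl compound stands apart from the alkyl pair as well as from compound 1. An aromatic ring on this chain carbon therefore does not by itself go with a low number, as compounds 1 and 2 sit at the two ends of the series, and nothing on hand gives a reason for any of these differences.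

Open, from the compounds shown here alone, is whether the chlorine of the 4-chlorobenzyl group is needed, which an unsubstituted benzyl group would test, and whether a longer chain such as hexyl would move toward compound 1 or stay with the short alkyl pair. Also open, going by these compounds, is how a chain ending in an amine would behave at this position, and whether a carboxylic acid in place of the ethyl ester would keep these differences.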